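Homologating the aminoalkyl chain on a shared core

The source may hold more compounds than are shown below. What is called first, only, known or untested is meant among the compounds shown, and "the series" means these compounds.

compound 1 `NCCN1C(=O)NC2(CSC3=C2C(=O)c2ccccc2C3=O)C1=O` — 22 nM; 20 nM; 31 nM (3 entries)
compound 2 `CCN(CC)CCN1C(=O)NC2(CSC3=C2C(=O)c2ccccc2C3=O)C1=O` — 21 nM

In a functional assay on MCF7 cells (Homo sapiens) for inhibition (on this read-out higher numbers stand for weaker inhibition and lower numbers for stronger inhibition), compound 1 gives 22 nM; 20 nM; 31 nM (3 entries) over repeated entries, as the several entries of compound 1 in this assay, 22 nM; 20 nM; 31 nM (3 entries) records. In this assay compound 2 gives 21 nM, which is the only number shown for it; one further entry carries no single number. The two values lie within the scatter of each other.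

Compound 3 `CCN(CC)CCCN1C(=O)NC2(CSC3=C2C(=O)c2ccccc2C3=O)C1=O` differs from compound 2 by (diethylamino)methyl in place of diethylamino on a saturated chain carbon, two bonds along the chain from an amide-type nitrogen in a ring. Going by the values given here, no step between measured compounds is available, so the expected step from compound 2 to compound 3 is placed within the scatter, at a 1.2-fold higher number from compound 2 to compound 3 (0.08 log units; within the scatter). Compound 3 is accordingly estimated at 25 nM, with a range from 10 nM to 60 nM.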

Compound 3, half-maximal inhibitory concentration: 26 nM
The estimate for compound 3 lay 1.0-fold (0.02 log units) below the measured number, and the stated range covers the measured number.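

Before this pair, no step between measured compounds was available at this position. Exchanging 2-(diethylamino)ethyl for 3-(diethylamino)propyl gives, in this assay, a 1.2-fold higher number from compound 2 to compound 3 (0.09 log units; within the scatter), so the number does not separate the two chain lengths. That step has to be read against how far repeated numbers for a single compound spread: the several entries of compound 1 in this assay, 22 nM; 20 nM; 31 nM (3 entries)

The compounds shown leave open whether a longer chain than 3-(diethylamino)propyl would hold the number. They also leave open what a carboxylic acid or a piperidine at the chain end would do.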